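The source may report more compounds than this note shows. Statements on the series, on what has been measured and on what is new or still open speak of the compounds shown alone.

Compound 3 `COc1ncnc2c1c(-c1ccsc1)cn2[C@@H]1O[C@H](CO)[C@@H](O)[C@H]1O` stands second highest of the three numbers measured in a functional assay on K562 cells (Homo sapiens), read by MTT assay, with a stated time of 72 h; a lower number here means a stronger inhibitor, a higher number a weaker inhibitor. In this assay compound 3 gives 90 nM. Its nearest neighbour is compound 2 `COc1ncnc2c1c(-c1ccco1)cn2[C@@H]1O[C@H](CO)[C@@H](O)[C@H]1O`, which in this assay gives 60 nM; the two lie within the scatter of each other. Furthest away is compound 1 `COc1nc(N)nc2c1c(-c1cc3ccccc3o1)cn2[C@@H]1O[C@H](CO)[C@@H](O)[C@H]1O`, which in this assay gives 14600 nM, beyond the scatter from compound 3.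

The next compound is compound 4 `COc1ncnc2c1c(-c1cc3ccccc3o1)cn2[C@@H]1O[C@H](CO)[C@@H](O)[C@H]1O`. It differs from compound 3 in one place: 1-benzofuran-2-yl in place of thiophen-3-yl on an aromatic carbon.

Going by the values given here, only one measured step touches the same position, a 1.5-fold higher number from compound 2 to compound 3 (0.18 log units; within the scatter), and it stays within the scatter. Among the compounds with values here, that step swaps one five-membered ring for another of like size, whereas the step to compound 4 brings in a fused two-ring group; no measured pair isolates that exchange. Compound 1 carries the same 1-benzofuran-2-yl group as compound 4 but also differs from it at a second place. Within the data shown here, the number that compound 1 gives, 14600 nM, therefore cannot be read as the effect of the ring change alone, yet it is the only number involving that group.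

Weighing the one small step against the weak number of compound 1, the step from compound 3 to compound 4 is expected to raise the number, a 6.7-fold higher number from compound 3 to compound 4 (0.82 log units; beyond the scatter), beyond the scatter. For compound 4 the estimated value in this assay is 600 nM, with a range from 120 nM to 4000 nM.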

Compound 4, half-maximal inhibitory concentration: 20900 nM
Estimate against measurement, compound 4: 35-fold (1.54 log units) below; the measured number lies above the stated range.
By their numbers in this assay, from the lowest: compounds 2 and 3 (each within the scatter of the next); then compounds 1 and 4 (each within the scatter of the next).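

In this assay, the position on this aromatic carbon proves far less tolerant than the earlier step suggested: exchanging one single five-membered ring for another gave a 1.5-fold higher number from compound 2 to compound 3 (0.18 log units; within the scatter) and stayed within the scatter, while the fused 1-benzofuran-2-yl group gives a 230-fold higher number from compound 3 to compound 4 (2.37 log units; beyond the scatter) and a 350-fold higher number from compound 2 to compound 4 (2.54 log units; beyond the scatter) as well, both large and beyond the scatter. The pair that differs only in hydrogen in place of amino, with a 1.4-fold higher number from compound 1 to compound 4 (0.16 log units; within the scatter) inside the scatter, shows that the weak number of compound 1 is matched without the amino group, so in this pair that group makes no readable difference, and the large loss appears with the 1-benzofuran-2-yl group on the unsubstituted core. Nothing at hand accounts for this loss.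

Going by these compounds, whether a single six-membered ring such as phenyl, or a fused group carrying sulfur such as 1-benzothiophen-2-yl, would sit with the small rings or with the 1-benzofuran-2-yl group remains open. Also open, on these data alone, is whether an amino group in place of hydrogen would leave the number unchanged when the furan-2-yl or thiophen-3-yl group occupies this position.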